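The source may report more compounds than this note shows. Statements on the series, on what has been measured and on what is new or still open speak of the compounds shown alone.

Compound 1 `Cc1cn(C2CC(N=[N+]=[N-])C(COC(=O)NCCCC(=O)OC(C)(C)C)O2)c(=O)[nH]c1=O` in a functional assay on MT4 cells (Homo sapiens) for cytotoxicity (on this read-out lower numbers stand for higher toxicity in this test and higher numbers for lower toxicity in this test), gives > 50000 nM, a limit of the assay.
Compound 2 `Cc1cn(C2CC(N=[N+]=[N-])C(COC(=O)OCCCCCCO)O2)c(=O)[nH]c1=O` in this assay gives > 50000 nM, again a limit.
Compound 3 `CCCCOC(=O)OCC1OC(n2cc(C)c(=O)[nH]c2=O)CC1N=[N+]=[N-]` in this assay gives > 50000 nM, also a limit.

Compound 3 therefore stands where all three measured compounds stand, at the limit of > 50000 nM in this assay, at which 3 of the 3 values shown sit, and no number separates it from the others. Within the data shown here, the one pairwise step among them, a step that the two limits leave unreadable from compound 2 to compound 3, is unreadable for the same reason.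

The next compound, compound 4 `Cc1cn(C2CC(N=[N+]=[N-])C(COC(=O)CCCN)O2)c(=O)[nH]c1=O`, differs from compound 3 in one place: 3-aminopropyl in place of butoxy on a carbonyl carbon. Among the measured compounds shown here, no measured step speaks to this change, and the measured steps that exist give no size at all, so there is no basis for expecting a step beyond the scatter in either direction in this assay. Compound 4 is accordingly expected to sit at the same limit as compound 3 in this assay, with a step that the limit leaves unreadable from compound 3 to compound 4 as the estimated step. Compound 4 is estimated at 100000 nM, within 30000 nM to 500000 nM, most probably reported again only as a limit.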

Compound 4, half-maximal cytotoxic concentration: > 50000 nM
Compound 4: only a limit was reported; the forecaster's own chance of this, stated with the estimate: 85%; the middle value is on the limit's open side.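

In this assay, among these compounds, compound 4 gives > 50000 nM and this is a limit, so no step from compound 2 or compound 3 to compound 4 can be read. The compounds shown leave open where each half-maximal cytotoxic concentration truly lies, and whether 3-aminopropyl in place of butoxy changes it at all.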